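From 3-hydroxyphenyl to 4-hydroxyphenyl in compound 4

The compounds below may be only part of what the source reports. "The series", "measured", "known", "first", "only" and "open" are said of these compounds alone.

Values measured so far in a functional assay on DU-145 cells (Homo sapiens) for cytotoxicity, read by ELISA, with a stated time of 2 days (a lower number here means a stronger inhibitor, a higher number a weaker inhibitor), are these
Compound 1 (`Oc1cccc(-c2cc(-c3ccccc3)cc(-c3cccs3)n2)c1`) gives 18900 nM
Compound 2 (`Oc1cccc(-c2cc(-c3ccccc3)cc(-c3ccsc3)n2)c1`) gives 11700 nM
Compound 3 (`Oc1cccc(-c2cc(-c3ccccc3)cc(-c3ccco3)n2)c1`) gives 14400 nM

Going by the values given here, compound 3 cannot be separated from the other two compounds, since a 1.2-fold higher number from compound 2 to compound 3 (0.09 log units; within the scatter) and a 1.3-fold lower number from compound 1 to compound 3 (0.12 log units; within the scatter) are its only steps and neither leaves the scatter. Compound 4 (`Oc1ccc(-c2cc(-c3ccccc3)cc(-c3ccco3)n2)cc1`) has the same atoms as compound 3 joined differently, and 4-hydroxyphenyl in place of 3-hydroxyphenyl on an aromatic carbon is the whole of the change. Among the compounds with values here, no measured step touches the hydroxyphenyl group. All three steps instead exchange furan-2-yl, thiophen-2-yl and thiophen-3-yl, and a 1.6-fold lower number from compound 1 to compound 2 (0.21 log units; within the scatter) also stays within the scatter. They are therefore only an indirect guide, and the data hold no direct test of this change. The step expected is a 1.0-fold lower number from compound 3 to compound 4 (0.01 log units; within the scatter) and so nothing beyond the scatter, in either direction. In this assay compound 4 is thus estimated at 14000 nM within an expected range from 6000 nM to 32000 nM as a cautious best guess.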

Compound 4, half-maximal inhibitory concentration: 3200 nM
Compound 4: the middle estimate sits 4.4-fold (0.64 log units) above what was measured, and the stated range ends above it.
By their numbers in this assay, from the lowest: compound 4; then compounds 2, 3 and 1 (each within the scatter of the next).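

Exchanging 3-hydroxyphenyl for 4-hydroxyphenyl gives a 4.5-fold lower number from compound 3 to compound 4 (0.65 log units; beyond the scatter) in this assay. This is the first step in the series to leave the scatter, whereas the exchanges among furan-2-yl, thiophen-2-yl and thiophen-3-yl all stayed within it, so the hydroxyphenyl group is the only place shown where a single change moves the number beyond the scatter. The two groups have the same heavy atoms, donors and acceptors, and nothing at hand accounts for the difference.

On these data alone, whether 4-hydroxyphenyl brings a similar drop alongside thiophen-2-yl or thiophen-3-yl remains open, since compound 1 and compound 2 carry only 3-hydroxyphenyl. Also open, as far as these compounds go, is what a methoxy group or an amine would do in place of the hydroxyl on this ring, and so whether the hydroxyl itself matters.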